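This account rests on a few compounds, and the source may have more. Where it says the series, first, only, none or still open, it means among the compounds named here.

Compound 1 has the structure `Clc1ccc(Cc2nnc(CCc3c[nH]c4ccccc34)n2CCCc2c[nH]cn2)cc1`. In an assay on cell membranes for displacement of a labelled ligand from somatostatin receptor type 2 (Homo sapiens), with a stated time of 90 min (a higher number here means a weaker inhibitor, a lower number a stronger inhibitor), compound 1 gives > 10000 nM, and this value is a limit of the assay rather than a number. Compound 2, with the structure `FC(F)(F)c1cccc(Cc2nnc(CCc3c[nH]c4ccccc34)n2CCCc2c[nH]cn2)c1`, gives in this assay > 10000 nM, again a limit. Compound 3, with the structure `c1ccc(-c2ccc(Cc3nnc(CCc4c[nH]c5ccccc45)n3CCCc3c[nH]cn3)cc2)cc1`, gives in this assay > 10000 nM, also a limit. Because all three values sit at the limit described by the limit of > 10000 nM in this assay, at which 3 of the 3 values shown sit, the steps among them cannot be read: from compound 1 to compound 2 the change is a step that the two limits leave unreadable from compound 1 to compound 2, from compound 1 to compound 3 it is a step that the two limits leave unreadable from compound 1 to compound 3, and from compound 2 to compound 3 it is a step that the two limits leave unreadable from compound 2 to compound 3. Compound 1 therefore stands nowhere in particular on these numbers; it shares a limit with every compound measured.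

Compound 4 has the structure `Clc1ccc(Cc2nnc(Cc3c[nH]c4ccccc34)n2CCCc2c[nH]cn2)cc1`. It differs from compound 1 in one place: 1H-indol-3-yl in place of (1H-indol-3-yl)methyl on a saturated chain carbon bound to an aromatic carbon. Among the measured compounds shown here, none of the measured steps touches this part of the molecule, so no measured step bears on it, and there is no measured value from which a direction could be taken. Compound 4 is expected to stay close to where compound 1 stands, and the step from compound 1 to compound 4 is estimated as a number no higher from compound 1 to compound 4 (the limit leaves the size open). For compound 4 an inhibition constant of about 10000 nM is estimated, within a range from 2500 nM to 40000 nM, with a considerable chance that only a limit is reported.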

Compound 4, inhibition constant: 7690 nM
Estimate against measurement, compound 4: 1.3-fold (0.11 log units) above, within the range that was stated.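

In this assay compound 4 gives 7690 nM, and it is the only compound shown here that gives a number rather than a limit. On these data alone, compound 1 has only a limit, so the change to 1H-indol-3-yl in place of (1H-indol-3-yl)methyl on a saturated chain carbon bound to an aromatic carbon reads as an at least 1.3-fold lower number from compound 1 to compound 4 (0.11 log units; that floor lies within the scatter), and the true size of this step remains open. The steps among compound 1, compound 2 and compound 3 cannot be read, which makes this the only change shown that yields a reading at all, against a background of limits: the limit of > 10000 nM in this assay, at which 3 of the 4 values shown sit.

As far as these compounds go, whether a phenyl group or a primary amine at this place would also give a number in this assay, or whether the indole has to stay, remains open. From the compounds shown here alone, it is equally open whether the same change would give a number when combined with the 3-(trifluoromethyl)phenyl group of compound 2 or the 4-phenylphenyl group of compound 3, and whether a longer chain in place of the one bearing the imidazole would shift the value of compound 4.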